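The source may report more compounds than this note shows. Statements on the series, on what has been measured and on what is new or still open speak of the compounds shown alone.

Measured compounds:
- compound 1, `COCc1nnc(N2CC3(CCc4cc(F)ccc4O3)C2)n1-c1ccc(OC)nc1`: 401 nM
- compound 2, `COc1ccc(-n2c(COC3CCOCC3)nnc2N2C[C@@H]3C[C@]3(c3ccc(F)cc3Cl)C2)cn1`: 826 nM

Series notes. In a functional assay on HEK293 cells for antagonist activity at Oxytocin receptor (Homo sapiens), read by calcium flux, with a stated time of 10 min, in the presence of a further agent that is not named here (on this read-out lower numbers stand for stronger inhibition and higher numbers for weaker inhibition), compound 1 gives 401 nM. In the same test compound 2 gives 826 nM, the higher of the two numbers, and its gap to compound 1 lies beyond the usual scatter of repeated measurements; the two compounds differ in several places, so nothing is tied to a single change.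

Compound 3, `COc1ccc(-n2c(C3CC3)nnc2N2C[C@@H]3C[C@]3(c3ccc(F)cc3Cl)C2)cn1`, has not been tested. It differs from compound 2 in one place: cyclopropyl in place of ((oxan-4-yl)oxy)methyl on an aromatic carbon. Among the measured compounds shown here, no measured pair shows this replacement, so the direction of the step is open. Compound 1 carries a smaller chain at the matching position and sits at the lower number, which is the only hint available.

Compound 3 is expected to give an inhibitory concentration near 550 nM, within a range of 150 nM to 2000 nM. The step from compound 2 to compound 3 is estimated at a 1.5-fold lower number from compound 2 to compound 3 (0.18 log units; within the scatter), which is not expected to exceed the scatter.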

Compound 3, half-maximal inhibitory concentration: 433 nM
Compound 3: the middle estimate sits 1.3-fold (0.10 log units) above what was measured; measured number inside the range.
By their numbers in this assay, from the lowest: compounds 1, 3 and 2 (each within the scatter of the next, the first and the last beyond it).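

In this assay, among the compounds shown here, replacing ((oxan-4-yl)oxy)methyl with cyclopropyl on the aromatic carbon of the five-membered ring gives a 1.9-fold lower number from compound 2 to compound 3 (0.28 log units; within the scatter), the first single-place step at this position. For this one pair on this core, a group of 8 heavy atoms with 2 hydrogen-bond acceptors and a group of 3 heavy atoms with 0 hydrogen-bond acceptors are not separated by the read-out, so the step gives no firm direction for this change. No supporting measurement bears on this result.

On these data alone, whether a primary amine, a carboxylic acid or a longer alkyl chain on this aromatic carbon would move the number beyond the scatter remains open, as a single pair does not show how far the position tolerates change. Compound 1 differs from compound 2 and compound 3 in several places, so the part played by its core and by the chain it carries at the matching position cannot be separated, and the step does not carry over to that core.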